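Replacing the pyrazinyl ring of compound 3 with an open-chain group

The source may report more compounds than this note shows. Statements on the series, on what has been measured and on what is new or still open speak of the compounds shown alone.

In a functional assay for activation of Alpha-1A adrenergic receptor (Homo sapiens), read by calcium flux (on this read-out lower numbers stand for an effect already at smaller amounts and higher numbers for an effect only at larger amounts of compound), compound 1 `c1coc(-c2ccccc2NCC2=NCCN2)c1` gives 0.468 nM and compound 2 `Cc1ccsc1-c1ccccc1NCC1=NCCN1` gives 0.851 nM, a pair separated by a 1.8-fold higher number from compound 1 to compound 2 (0.26 log units; within the scatter). Compound 3 `c1ccc(-c2cnccn2)c(NCC2=NCCN2)c1` gives 4.57 nM, the highest number of the three, set apart by a 9.8-fold higher number from compound 1 to compound 3 (0.99 log units; beyond the scatter) and a 5.4-fold higher number from compound 2 to compound 3 (0.73 log units; beyond the scatter). Compound 4 `CC/C(=N/OC)c1ccccc1NCC1=NCCN1` differs from compound 3 by a group of 6 heavy atoms (4 carbon, 1 nitrogen, 1 oxygen; no ring) in place of a group of 6 heavy atoms (4 carbon, 2 nitrogen; one six-membered aromatic ring with 2 hetero atoms), on an aromatic carbon. Going by the values given here, those two steps show only that pyrazin-2-yl raised the number relative to two five-membered aromatic rings; no measured step swaps a ring for a group without a ring, so the direction for compound 4 is uncertain. Compound 4 is therefore expected near compound 3, with a 1.3-fold lower number from compound 3 to compound 4 (0.12 log units; within the scatter), at an estimated 3.5 nM, between 0.6 nM and 20 nM.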

Compound 4, half-maximal effective concentration: 87.1 nM
Compound 4: middle estimate off by 25-fold (1.40 log units), on the low side; the whole stated range lies below it.
By their numbers in this assay, from the lowest: compounds 1 and 2 (each within the scatter of the next); then compound 3; then compound 4.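

Going by these compounds alone, at this place on the aromatic carbon, the earlier compounds compared only rings, whereas compound 4 carries an open-chain group. In this assay, this change gives higher numbers against all three ring-bearing compounds, whichever ring they carry: a 19-fold higher number from compound 3 to compound 4 (1.28 log units; beyond the scatter) and a 100-fold higher number from compound 2 to compound 4 (2.01 log units; beyond the scatter) and a 190-fold higher number from compound 1 to compound 4 (2.27 log units; beyond the scatter). Nothing measured here accounts for this shift.

As far as these compounds go, whether any group without a ring can match the rings stays open. A plain propyl chain or a dimethylamino group in the same place would help separate losing the ring from the particular open-chain group of compound 4.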